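The source may hold more compounds than are shown below. What is called first, only, known or untested is meant among the compounds shown, and "the series" means these compounds.

In a functional assay on HOP-92 cells (Homo sapiens) for inhibition, read by sulforhodamine B assay, with a stated time of 48 h (on this read-out lower numbers stand for stronger inhibition of growth and higher numbers for weaker inhibition of growth), compound 1 `COc1cc2cc(Oc3ccc(NC(=O)Nc4cccc(C(F)(F)F)c4)cc3)c(C)nc2cc1OC` gives 1260 nM. Compound 2 `COc1cc2cc(Oc3ccc(NC(=O)Nc4ccc(Cl)c(C(F)(F)F)c4)cc3)c(C)nc2cc1OC` gives 682 nM in this assay, and the step of a 1.8-fold lower number from compound 1 to compound 2 (0.27 log units; within the scatter) is the only one measured so far. On these two numbers compound 2 has the lowest value, with compound 1 as its nearest neighbour at a distance that stays within the scatter, so the two cannot be ranked against each other.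

Compound 3 `COc1cc2cc(Oc3ccc(NC(=O)Nc4ccc(Cl)c(Cl)c4)cc3)c(C)nc2cc1OC` differs from compound 2 by chloro in place of trifluoromethyl on an aromatic carbon, the new chloro sitting ortho to a chloro group and meta to a large group. Within the data shown here, no measured step covers this exchange: the one step at hand changed a different place, from hydrogen to chloro, and stayed within the scatter. Among the measured compounds shown here, since both the urea part and the shared core are untouched and the only known step was small, a change of no more than the scatter is expected, a 1.3-fold higher number from compound 2 to compound 3 (0.12 log units; within the scatter). Compound 3 is therefore estimated at 900 nM in this assay, with a range from 400 nM to 2000 nM.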

Compound 3, concentration for 50% growth inhibition: 2040 nM
For compound 3 the middle estimate is 2.3-fold (0.36 log units) below the measured one, outside the stated range (above it).
By their numbers in this assay, from the lowest: compounds 2, 1 and 3 (each within the scatter of the next, the first and the last beyond it).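

In this assay, the place ortho to a chloro group and meta to a large group proves sensitive to what it carries: putting chloro where trifluoromethyl stood gives a 3.0-fold higher number from compound 2 to compound 3 (0.48 log units; beyond the scatter), a modest change, but the first one in this small series to lie beyond the scatter. Measured against the unchlorinated starting point, the picture is less clear, since the change of 3-(trifluoromethyl)phenyl to 3,4-dichlorophenyl gives a 1.6-fold higher number from compound 1 to compound 3 (0.21 log units; within the scatter), so those two aryl groups cannot be told apart on this read-out. The trifluoromethyl group therefore matters here only in the presence of the chloro group already on the ring, and even then on the evidence of one pair, and nothing available gives a reason for the step.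

The compounds shown leave open how other groups at this place, such as methyl, methoxy or nitrile, would compare with trifluoromethyl and chloro. They also leave open whether the same exchange would give a step of similar size on a changed core or with an amine added to it.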